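A few compounds are considered here, and "the series" means these few. Any claim that something is new, unique, unknown or untested is made for them only; others in the source may bear on it.

Compound 1 `Nc1nc(N)c2c(-c3ccccc3)cn([C@@H]3O[C@H](CO)[C@@H](O)[C@H]3O)c2n1` — > 20000 nM in a functional assay on K562 cells (Homo sapiens), read by MTT assay, with a stated time of 72 h; a higher number here means a weaker inhibitor, a lower number a stronger inhibitor.
Compound 2 `COc1nc(N)nc2c1c(-c1ccoc1)cn2[C@@H]1O[C@H](CO)[C@@H](O)[C@H]1O` — > 20000 nM in this assay.

Both of these values are limits of this assay, not numbers. Compound 2 stands at the limit of > 20000 nM in this assay, at which 2 of the 2 values shown sit, so its result tells only that it was not a measurable inhibitor there. Compound 1 gives the same limit, and the two therefore cannot be ordered against each other.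

Compound 3 `Nc1nc(N)c2c(-c3ccoc3)cn([C@@H]3O[C@H](CO)[C@@H](O)[C@H]3O)c2n1` is the compound not yet measured. It differs from compound 2 by a single change: amino in place of methoxy on an aromatic carbon. Compound 1 already carries amino at that same place and sits at the same limit as compound 2.

Within the data shown here, with both measured compounds at the limit, no step between them can be sized. The change to compound 3 is expected to leave the result where the others lie: the step that the limit leaves unreadable from compound 2 to compound 3 is estimated as none beyond the scatter. Compound 3 is expected to give about 30000 nM in this assay, within 8000 nM to 100000 nM, most likely again reported as a limit.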

Compound 3, half-maximal inhibitory concentration: > 20000 nM
Compound 3: a limit, no number; the forecaster's own chance of this, stated with the estimate: 80%; the middle value does not contradict the limit.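

Compound 3 joins compound 1 and compound 2 at the same limit, so no step from either of them to compound 3 can be read: the limit of > 20000 nM in this assay, at which 3 of the 3 values shown sit.

The compounds shown leave open whether amino in place of methoxy, or furan-3-yl in place of phenyl, changes the result in this assay at all.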